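Dropping the methoxy group from compound 3

A few compounds are considered here, and "the series" means these few. Any claim that something is new, unique, unknown or untested is made for them only; others in the source may bear on it.

In a functional assay on HL-60 cells (Homo sapiens) for inhibition, read by CCK-8 assay, with a stated time of 48 h, tested at 20 uM (on this read-out higher numbers stand for more inhibition of growth at the one concentration tested and lower numbers for less inhibition of growth), compound 1 `COc1ccc(Cc2nnc(NC(=O)/C(C#N)=C/c3ccccc3OS(=O)(=O)c3ccc([N+](=O)[O-])cc3)s2)cc1` gives 51%, compound 2 `COc1ccc(Cc2nnc(NC(=O)/C(C#N)=C/c3ccccc3OS(=O)(=O)c3ccc(Cl)cc3)s2)cc1` gives 20% and compound 3 `COc1ccc(Cc2nnc(NC(=O)/C(C#N)=C/c3ccccc3OS(=O)(=O)c3ccc(F)cc3)s2)cc1` gives 25%. Compound 3 stands level with compound 2, as the data show a number 5 percentage points higher from compound 2 to compound 3 (within the scatter). Compound 1 stands apart from both, with a number 31 percentage points lower from compound 1 to compound 2 (beyond the scatter) and a number 26 percentage points lower from compound 1 to compound 3 (beyond the scatter).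

Compound 4 `N#C/C(=C\c1ccccc1OS(=O)(=O)c1ccc(F)cc1)C(=O)Nc1nnc(Cc2ccccc2)s1` differs from compound 3 in one place: hydrogen in place of methoxy on an aromatic carbon, turning 4-methoxybenzyl into benzyl (hydrogen in place of methoxy on an aromatic carbon). All three measured steps swap nitro, chloro or fluoro at a different place, so none of them tests the methoxy group directly. Within the data shown here, they show only that a single swap can move the number a long way or hardly at all. The best guide is therefore compound 3 itself, at 25%, and no step beyond the scatter is expected, though one in either direction remains possible. The expected change is a number 2 percentage points lower from compound 3 to compound 4 (within the scatter). The estimate for compound 4 is 23%, with a range of 10% to 40%.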

Compound 4, percent growth inhibition at one concentration: 22%
Compound 4: the middle estimate sits 1 percentage points above what was measured; low and high end bracket the measured number.
By their numbers in this assay, from the lowest: compounds 2, 4 and 3 (each within the scatter of the next); then compound 1.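

Replacing the methoxy group with hydrogen, which turns 4-methoxybenzyl into benzyl, gives a number 3 percentage points lower from compound 3 to compound 4 (within the scatter) in this assay. Among these compounds, this is the first direct test of this position, and with fluoro kept in place, the methoxy group makes no difference beyond the scatter to growth inhibition at the one concentration tested. No supporting measurement bears on why the two compounds read alike.

On these data alone, it remains open whether the same swap would also leave the number within the scatter in the nitro series, where compound 1 gives 51%. Also open, as far as these compounds go, is how a different group at this ring carbon, such as an amine, a carboxylic acid or a longer alkoxy chain, would read, since hydrogen and methoxy are the only two compared here.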